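The compounds below may be only part of what the source reports. "The series", "measured", "known", "first", "only" and "open" are said of these compounds alone.

Compound 1 `COc1ccc(C(=O)Nc2cccc(-c3ccnc4c(N)cccc34)c2)cc1OC` is, in a functional assay on A375P cells (Homo sapiens) for antiproliferative activity, read by MTT assay, with a stated time of 48 h (a higher number here means a weaker inhibitor, a lower number a stronger inhibitor), the weaker-looking of two measured compounds, giving 9500 nM; compound 2 `Nc1cccc2c(-c3cccc(NC(=O)c4cccc(C(F)(F)F)c4)c3)ccnc12` gives 7900 nM in this assay, and the step of a 1.2-fold lower number from compound 1 to compound 2 (0.08 log units; within the scatter) is within the scatter. Compound 3 `COc1ccc(C(=O)Nc2cccc(-c3ccnc4c(NC(C)=O)cccc34)c2)cc1OC` differs from compound 1 by acetyl in place of hydrogen on a nitrogen on an aromatic ring. Among the measured compounds shown here, the only measured step alters the aryl on the carbonyl carbon, not the amino group on the core, so no measured step bears on this change. Compound 3 is therefore expected to stay near compound 1, with the estimated step of a 1.2-fold higher number from compound 1 to compound 3 (0.06 log units; within the scatter). The estimate for compound 3 is 11000 nM, in the range 3000 nM to 40000 nM.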

Compound 3, half-maximal inhibitory concentration: 5300 nM
Beside the measured number, compound 3's estimate is 2.1-fold (0.32 log units) above it; low and high end bracket the measured number.
By their numbers in this assay, from the lowest: compounds 3, 2 and 1 (each within the scatter of the next).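

In this assay, acetyl in place of hydrogen on the aromatic amino nitrogen gives a 1.8-fold lower number from compound 1 to compound 3 (0.25 log units; within the scatter). Among the compounds shown here, this is the first look at this nitrogen, and it shows that turning amino into acetamido, with the 3,4-dimethoxyphenyl group kept, leaves the number within the scatter. Nothing measured here offers a reason for this result.

Going by these compounds, it remains open whether a methyl, a benzoyl or a methanesulfonyl group on this nitrogen would behave the same way. On these data alone, it is also open whether acetyl would do so alongside the 3-(trifluoromethyl)phenyl group of compound 2.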